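Series notes: aryl exchange on the shared core

The source may hold more compounds than are shown below. What is called first, only, known or untested is meant among the compounds shown, and "the series" means these compounds.

Measured so far, in a functional assay on HepG2 cells (Homo sapiens) for inhibition, read by CCK-8 assay, with a stated time of 48 h; a lower number here means a stronger inhibitor, a higher number a weaker inhibitor:
compound 1 `Fc1ccc(C2=NN(C3=NC(c4ccccc4)CS3)C(c3cccc4ccccc34)C2)cc1` gives 23200 nM
compound 2 `Cc1ccc(C2=NN(C3=NC(=O)CS3)C(c3ccc4ccccc4c3)C2)cc1` gives 12700 nM
compound 3 `Fc1ccc(C2=NN(C3=NC(c4ccccc4)CS3)C(c3ccc4ccccc4c3)C2)cc1` gives 26500 nM

Compound 3 carries the highest of the three numbers. Its nearest neighbour is compound 1: the step of a 1.1-fold higher number from compound 1 to compound 3 (0.06 log units; within the scatter) is within the scatter, so the two cannot be ordered. For the measured compounds named here, compound 2 gives 12700 nM, and the gap to compound 3 lies beyond the scatter, but compound 2 differs in more than one place, so no single step is attributed to it.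

Compound 4 `Cc1ccc(C2=NN(C3=NC(c4ccccc4)CS3)C(c3ccc4ccccc4c3)C2)cc1C` is not yet measured. It differs from compound 3 by 3,4-dimethylphenyl in place of 4-fluorophenyl on a carbon with a double bond to nitrogen. Going by the values given here, no measured step in this assay touches the group on that carbon; the only step available, from compound 1 to compound 3, concerns the naphthyl group on a saturated ring carbon and was within the scatter. Compound 2, which carries a 4-methylphenyl there, also differs elsewhere and gives no clean reading.

Among the compounds with values here, with no step bearing on this change, the expectation for compound 4 is no step beyond the scatter, a 1.2-fold lower number from compound 3 to compound 4 (0.08 log units; within the scatter), from compound 3. The estimate for compound 4 in this assay is therefore 22000 nM, with a range from 8000 nM to 60000 nM.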

Compound 4, half-maximal inhibitory concentration: 7370 nM
Compound 4: the middle estimate sits 3.0-fold (0.47 log units) above what was measured; the measured number lies below the stated range.
By their numbers in this assay, from the lowest: compounds 4, 2, 1 and 3 (each within the scatter of the next, the first and the last beyond it).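

In this assay, the exchange of 4-fluorophenyl for 3,4-dimethylphenyl on the carbon with a double bond to nitrogen gives a 3.6-fold lower number from compound 3 to compound 4 (0.56 log units; beyond the scatter). For the compounds shown here, this is the first step to read this position, and it shows that the group there can move the number beyond the scatter, unlike the naphthyl exchange in a 1.1-fold higher number from compound 1 to compound 3 (0.06 log units; within the scatter), which stayed within it. Both groups are six-membered aromatic rings of carbon only, with no hydrogen-bond donors or acceptors and no net charge, so the counted features stay the same across the step, and no measurement shown here accounts for its size.

The compounds shown do not separate the loss of fluorine from the gain of the two methyl groups. Compound 2 carries a 4-methylphenyl at this position but also differs elsewhere, so it cannot separate them. Also open, going by these compounds, is how an amine, a carboxylic acid or a methoxy group on this aryl ring would read, and whether the same exchange gives a similar step with the naphthalen-1-yl group of compound 1.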